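A few compounds are considered here, and "the series" means these few. Any claim that something is new, unique, unknown or untested is made for them only; others in the source may bear on it.

Values in a functional assay on P388 cells (Mus musculus) for cytotoxicity; on this read-out higher numbers stand for weaker inhibition and lower numbers for stronger inhibition

Compound 1 `Cc1cc(-c2c(F)cc3c(=O)c(Cc4c(O)cccc4O)cn(C4CC4)c3c2F)cc(C)n1` gives 250 nM
Compound 2 `Cc1cc(-c2c(F)cc3c(=O)c(Cc4ccccc4)cn(C4CC4)c3c2F)cc(C)n1` gives 7300 nM
Compound 3 `Cc1cc(-c2c(F)cc3c(=O)c(Cc4cccc(O)c4O)cn(C4CC4)c3c2F)cc(C)n1` gives 880 nM
Compound 4 `Cc1cc(-c2c(F)cc3c(=O)c(Cc4ccccc4N)cn(C4CC4)c3c2F)cc(C)n1` has not been measured

Compound 3 stands second highest of the three numbers, with compound 1 lower and compound 2 higher. The next change, to compound 4, is 2-aminophenyl in place of 2,3-dihydroxyphenyl on a saturated chain carbon bound to an aromatic carbon and amounts to 2-aminophenyl in place of 2,3-dihydroxyphenyl on a saturated chain carbon bound to an aromatic carbon. Three measured steps at this place bear on it: a 29-fold higher number from compound 1 to compound 2 (1.47 log units; beyond the scatter) is large, while an 8.3-fold lower number from compound 2 to compound 3 (0.92 log units; beyond the scatter) and a 3.5-fold higher number from compound 1 to compound 3 (0.55 log units; beyond the scatter) are modest. Among the compounds with values here, no amino compound has been measured, so these steps only bracket the change. A modest step to a higher number is expected in this assay and the number expected for compound 4 lies lower than that of compound 2, which gives 7300 nM. The estimated step is a 2.3-fold higher number from compound 3 to compound 4 (0.36 log units; beyond the scatter). For compound 4 the estimated value is 2000 nM, with an expected range from 600 nM to 6000 nM.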

Compound 4, half-maximal inhibitory concentration: 2100 nM
Compound 4: the middle estimate sits 1.1-fold (0.02 log units) below what was measured, and the stated range covers the measured number.
By their numbers in this assay, from the lowest: compound 1; then compound 3; then compound 4; then compound 2.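

In this assay, a single amino group on the ring is enough to lower the number, with a 3.5-fold lower number from compound 2 to compound 4 (0.54 log units; beyond the scatter), so this position responds to a substituent other than hydroxyl. The 2-aminophenyl group still falls short of both dihydroxyphenyl groups, with a 2.4-fold higher number from compound 3 to compound 4 (0.38 log units; beyond the scatter) and an 8.4-fold higher number from compound 1 to compound 4 (0.92 log units; beyond the scatter). No measurement on hand explains this order.

Open, going by these compounds, is whether a single hydroxyl, as in 2-hydroxyphenyl, would match the 2-aminophenyl number. Also open, on these data alone, is whether a methoxy group or a carboxylic acid on the ring would lower the number at all.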